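The compounds below may be only part of what the source reports. "The series", "measured", "known", "first", "only" and "open" are said of these compounds alone.

Compound 1 `Cc1cc(-c2ccco2)cn2c(CSCCc3ccccc3)cnc12` gives 40 ug/mL in an ADME assay on HEL cells (Homo sapiens) for cytotoxicity, with a stated time of 3 days (on this read-out lower numbers stand for higher toxicity in this test and higher numbers for lower toxicity in this test), the highest of the three numbers shown, though its gap to compound 2 lies within the scatter. Compound 2 `Cc1cc(-n2ccnc2)cn2c(CSCCc3ccccc3)cnc12` gives 23 ug/mL in this assay, and compound 3 `Cc1cc(-n2ccc3cccnc32)cn2c(CSCCc3ccccc3)cnc12` gives 16 ug/mL in this assay; the steps are a 1.7-fold lower number from compound 1 to compound 2 (0.24 log units; within the scatter) and a 2.5-fold lower number from compound 1 to compound 3 (0.40 log units; beyond the scatter), while a 1.4-fold lower number from compound 2 to compound 3 (0.16 log units; within the scatter). Compound 4 `Cc1cc(C#N)cn2c(CSCCc3ccccc3)cnc12` differs from compound 1 by cyano in place of furan-2-yl on an aromatic carbon. For the measured compounds named here, the two steps from compound 1 both swap the furan-2-yl for a larger ring group, not a cyano, and the single step beyond the scatter is only modest, so no step beyond the scatter is expected here, with at most a slight lean toward a lower number. Compound 4 is therefore estimated at 35 ug/mL in this assay, within 14 ug/mL to 90 ug/mL, which is expected to mean a 1.1-fold lower number from compound 1 to compound 4 (0.06 log units; within the scatter).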

Compound 4, half-maximal cytotoxic concentration: 14 ug/mL
For compound 4 the middle estimate is 2.5-fold (0.40 log units) above the measured one; low and high end bracket the measured number.
By their numbers in this assay, from the lowest: compounds 4, 3, 2 and 1 (each within the scatter of the next, the first and the last beyond it).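

Cyano is the first group at this position without a ring, and in this assay putting it in place of furan-2-yl gives a 2.9-fold lower number from compound 1 to compound 4 (0.46 log units; beyond the scatter). Against the other two groups it gives a 1.1-fold lower number from compound 3 to compound 4 (0.06 log units; within the scatter) and a 1.6-fold lower number from compound 2 to compound 4 (0.22 log units; within the scatter), so across these compounds the number does not follow the size of the group, as the smallest and the largest lie within the scatter of each other. Nothing available here explains this result. As far as these compounds go, whether an amine, a carboxylic acid or a longer alkyl chain at this position would give a number near those of compound 4 or compound 1 remains open.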